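A few compounds are considered here, and "the series" means these few. Any claim that something is new, unique, unknown or untested is made for them only; others in the source may bear on it.

Working notes on the series.

The series shares one core, carried by compound 1 `COc1ccc(N2CCN(Cn3nc(-c4ccc5c(c4)OCCO5)oc3=S)CC2)cc1`, compound 2 `O=[N+]([O-])c1ccc(N2CCN(Cn3nc(-c4ccc5c(c4)OCCO5)oc3=S)CC2)cc1`, compound 3 `S=c1oc(-c2ccc3c(c2)OCCO3)nn1CN1CCN(c2ccccc2Cl)CC1` and the unmeasured compound 4 `S=c1oc(-c2ccc3c(c2)OCCO3)nn1CN1CCN(c2ccccc2)CC1`. Among the compounds with values here, in a functional assay on BGC-823 cells (Homo sapiens) for antiproliferative activity, read by MTT assay, with a stated time of 48 h (on this read-out lower numbers stand for stronger inhibition and higher numbers for weaker inhibition), compound 1 gives 18900 nM, the only plain number in the set. Compound 2 reaches only a limit of this assay, > 50000 nM. Compound 3 likewise reaches only a limit, > 50000 nM. Both limits sit at the limit of > 50000 nM in this assay, at which 2 of the 3 values shown sit, so compound 1 stands as the sole measured point of reference.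

The change from compound 1 to compound 4 is hydrogen in place of methoxy on an aromatic carbon, a trimming of the aryl group on the amine nitrogen in the ring. The measured steps that bear on it both alter the same aryl group and both go in the same direction: an at least 2.6-fold higher number from compound 1 to compound 2 (0.42 log units; beyond the scatter), and an at least 2.6-fold higher number from compound 1 to compound 3 (0.42 log units; beyond the scatter). The remaining step, a step that the two limits leave unreadable from compound 2 to compound 3, adds nothing readable. Two changes at this group each weaken inhibition; the change to compound 4 is the smallest of the three and could fall within the scatter.

For compound 4 a modest rise in the number is therefore expected, a 1.6-fold higher number from compound 1 to compound 4 (0.20 log units; within the scatter). The estimate for compound 4 in this assay is 30000 nM, in a range from 12000 nM to 60000 nM.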

Compound 4, half-maximal inhibitory concentration: > 50000 nM
Compound 4: a limit, no number (the forecaster's own chance of this, stated with the estimate: 35%); middle value at least 1.6-fold (0.22 log units) away from the limit.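

Taking the methoxy off the aromatic carbon, with only hydrogen left in its place, gives an at least 2.6-fold higher number from compound 1 to compound 4 (0.42 log units; beyond the scatter) in this assay. Compound 2 and compound 3 replaced the group with a nitro-bearing or chlorine-bearing aryl group, so they could not show whether the loss needed a new substituent; compound 4 shows that the bare phenyl also gives a loss beyond the scatter, and among the four compounds no change away from 4-methoxyphenyl goes against this. The value of compound 4 is a limit, not a number, and it joins those of compound 2 and compound 3, which leaves the steps among these three unreadable and compound 1 as the only plain number: the limit of > 50000 nM in this assay, at which 3 of the 4 values shown sit.

Open, going by these compounds, is whether the oxygen, the methyl or the whole methoxy group carries the effect, which a hydroxyl, an ethoxy or an amine at the same place on the ring would begin to separate. Also open, on these data alone, is how far compound 2, compound 3 and compound 4 lie beyond the limit, and so whether any order exists among them.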